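Replacing the Ethyl Ether with a Thiophene Ring

A few compounds are considered here, and "the series" means these few. Any claim that something is new, unique, unknown or untested is made for them only; others in the source may bear on it.

For the measured compounds named here, compound 2 `CCOc1ccc2c(c1)C(=O)C=CC2=O` gives 21400 nM in a functional assay on KB cells (Homo sapiens) for cytotoxicity (on this read-out lower numbers stand for stronger inhibition and higher numbers for weaker inhibition), the highest of the two numbers measured so far. Going by the values given here, compound 1 `C=CCOc1ccc2c(c1)C(=O)C=CC2=O` gives 10200 nM, and the only measured step, a 2.1-fold higher number from compound 1 to compound 2 (0.32 log units; beyond the scatter), shows that a small change on this chain can move the result beyond the scatter. Compound 3 `O=C1C=CC(=O)c2cc(Oc3cccs3)ccc21` differs from compound 2 by thiophen-2-yl in place of ethyl on an oxygen on an aromatic ring. Among the compounds with values here, no measured step covers a ring entering at this oxygen, so the single step bears only loosely on it. The expected step is a 1.8-fold lower number from compound 2 to compound 3 (0.25 log units; within the scatter), leaning toward a lower number. Compound 3 is therefore estimated at 12000 nM, within 3000 nM to 50000 nM.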

Compound 3, half-maximal inhibitory concentration: 18300 nM
Beside the measured number, compound 3's estimate is 1.5-fold (0.18 log units) below it, and the stated range covers the measured number.
By their numbers in this assay, from the lowest: compounds 1, 3 and 2 (each within the scatter of the next, the first and the last beyond it).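

Putting thiophen-2-yl on this oxygen in place of ethyl gives a 1.2-fold lower number from compound 2 to compound 3 (0.07 log units; within the scatter), so this aromatic ring and the open chain cannot be told apart here. Set against allyl, the same ring gives a 1.8-fold higher number from compound 1 to compound 3 (0.25 log units; within the scatter), also too small a gap to separate the two. Thus, a ring can stand on this oxygen with the number staying within the scatter of either chain, and nothing measured explains why. Still open, on these data alone, is whether an amine, a carboxylic acid or a longer chain on this oxygen would shift the number, and whether a phenyl ring would match thiophen-2-yl.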